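Removing the Ring Fluorine from Compound 3

The source may report more compounds than this note shows. Statements on the series, on what has been measured and on what is new or still open speak of the compounds shown alone.

Of the compounds shown here, three sharing one core have been measured in an assay on CHO cells for displacement of a labelled ligand from adenosine receptor A2b (Homo sapiens), read by scintillation counting, with a stated time of 75 min, in the presence of a further agent that is not named here; a higher number here means a weaker inhibitor, a lower number a stronger inhibitor. Compound 1 `CCCn1c(=O)[nH]c2nc(-c3ccc(S(=O)(=O)N4CCN(c5ccc(F)cc5)CC4)cc3)[nH]c2c1=O` gives 0.644 nM. Compound 2 `CCCn1c(=O)[nH]c2nc(-c3ccc(S(=O)(=O)N4CCN(c5ccc(Cl)cc5F)CC4)cc3)[nH]c2c1=O` gives 1.91 nM. Compound 3 `CCCn1c(=O)[nH]c2nc(-c3ccc(S(=O)(=O)N4CCN(c5ccccc5F)CC4)cc3)[nH]c2c1=O` gives 3.22 nM, the highest of the three numbers. Its nearest neighbour is compound 2, with a 1.7-fold higher number from compound 2 to compound 3 (0.23 log units; within the scatter), a gap within the scatter; the step of a 5.0-fold higher number from compound 1 to compound 3 (0.70 log units; beyond the scatter) is beyond the scatter, as is a 3.0-fold higher number from compound 1 to compound 2 (0.47 log units; beyond the scatter).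

Compound 4 `CCCn1c(=O)[nH]c2nc(-c3ccc(S(=O)(=O)N4CCN(c5ccccc5)CC4)cc3)[nH]c2c1=O` differs from compound 3 by hydrogen in place of fluoro on an aromatic carbon. For the measured compounds named here, no measured step removes this fluoro; the closest bearings are the step of a 1.7-fold higher number from compound 2 to compound 3 (0.23 log units; within the scatter), which removed a chloro and stayed within the scatter, and the step of a 5.0-fold higher number from compound 1 to compound 3 (0.70 log units; beyond the scatter), which moved the fluoro and was modest. A step no larger than these is therefore expected in this assay, most likely toward a somewhat lower number, or none beyond the scatter. Compound 4 is expected to give 2.5 nM, within a range from 1 nM to 6.5 nM, the expected step being a 1.3-fold lower number from compound 3 to compound 4 (0.11 log units; within the scatter).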

Compound 4, inhibition constant: 0.643 nM
Beside the measured number, compound 4's estimate is 3.9-fold (0.59 log units) above it; the measured number lies below the stated range.
By their numbers in this assay, from the lowest: compounds 4 and 1 (each within the scatter of the next); then compounds 2 and 3 (each within the scatter of the next).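

The fluoro on the aromatic carbon ortho to a large group now stands out as a group whose removal alone shifts the result in this assay, with a 5.0-fold lower number from compound 3 to compound 4 (0.70 log units; beyond the scatter); the earlier compounds had shown only a change in where the fluoro sat. The unsubstituted phenyl also matches the 4-fluorophenyl, with a 1.0-fold lower number from compound 1 to compound 4 (0.00 log units; within the scatter), so the fluoro of compound 1 shows no gain or loss against hydrogen. Replacing the whole 4-chloro-2-fluorophenyl with phenyl gives a 3.0-fold lower number from compound 2 to compound 4 (0.47 log units; beyond the scatter), and across these four compounds, the two carrying a fluoro at this ortho place, compound 2 and compound 3, have the higher numbers.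

From the compounds shown here alone, whether a methyl or methoxy group at this place would act as the fluoro does remains open. Nothing shown here explains the step.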